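Fluoro for Methyl on an Outer Ring of a Urea

A few compounds are considered here, and "the series" means these few. Any claim that something is new, unique, unknown or untested is made for them only; others in the source may bear on it.

Three compounds have been measured so far in an assay on isolated protein for inhibition of STE20-like serine/threonine-protein kinase (Homo sapiens), read by thermal shift assay, tested at 10 uM; a lower number here means that the compound stabilises the target less, a higher number that the compound stabilises the target more against heat:
Compound 1 `Cc1ccc(F)cc1NC(=O)Nc1cc(C(C)(C)C)nn1-c1ccccc1`: 6 degrees C
Compound 2 `Cc1ccc(S(=O)(=O)NC(=O)Nc2cc(C(C)(C)C)nn2-c2ccccc2)cc1`: -0.3 degrees C
Compound 3 `Cc1ccc(-n2nc(C(C)(C)C)cc2NC(=O)Nc2cc(F)cc(F)c2)cc1`: 2.8 degrees C

Among these three numbers compound 3 stands second highest. Its nearest neighbour is compound 2, which lies lower by a margin beyond the scatter, and its furthest is compound 1, which lies higher, again beyond the scatter.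

Compound 4 `CC(C)(C)c1cc(NC(=O)Nc2cc(F)cc(F)c2)n(-c2ccc(F)cc2)n1` differs from compound 3 by a single swap: fluoro in place of methyl on an aromatic carbon. Among the measured compounds shown here, no measured pair shows this same change, so there is no measured step to lean on. The expected step in this assay is no change at the digits printed from compound 3 to compound 4 (within the scatter), no larger than the scatter in either direction. Compound 4 is therefore estimated at 2.8 degrees C, with a range from 1 degrees C to 4.5 degrees C.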

Compound 4, shift of the target's melting temperature: 2.7 degrees C
The estimate for compound 4 lay 0.10 degrees C above the measured number; the range from low to high includes it.
By their numbers in this assay, from the lowest: compound 2; then compounds 4 and 3 (each within the scatter of the next); then compound 1.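

Among the compounds shown here, compound 3 and compound 4 form the first measured pair here that differs in one place. In this assay, changing 4-methylphenyl to 4-fluorophenyl gives a number 0.10 degrees C lower from compound 3 to compound 4 (within the scatter), so at this position the two groups cannot be told apart in this read-out. Nothing available explains why they read alike. This single pair cannot show whether the same swap would behave alike elsewhere on the shared core. From the compounds shown here alone, whether an amine or a carboxylic acid at this position would also leave the number unchanged remains open.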